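A Larger Amide in Place of a Nitrile

The compounds below may be only part of what the source reports. "The series", "measured", "known", "first", "only" and "open" are said of these compounds alone.

The measured compounds and what they show in a functional assay on NCI-H460 cells (Homo sapiens) for inhibition, with a stated time of 48 h; on this read-out lower numbers stand for stronger inhibition of growth and higher numbers for weaker inhibition of growth:

Compound 1, `N#Cc1ccc(-n2ncc3c(N)ncnc32)cc1`: "not determined" (no result reported)
Compound 2, `Nc1ncnc2c1cnn2-c1ccc(C(=O)O)cc1`: "not determined" (no result reported)
Compound 3, `CC(=O)OC[C@H]1O[C@@H](Nc2ncnc3c2cnn3-c2ccc(C(=O)O)cc2)[C@H](OC(C)=O)[C@@H](OC(C)=O)[C@@H]1OC(C)=O`: > 150000 nM, which is a limit of the assay and not a number.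

Compound 1 thus stands without a number of its own in this assay. The entry for compound 2 carries no number either, and the only reported result in the set, that of compound 3, is a limit, (the limit of > 150000 nM in this assay, at which 1 of the 3 values shown sits). Within the data shown here, nothing among the measured compounds tells how strongly compound 1 itself inhibits growth.

Compound 4, `COC(=O)CNC(=O)c1ccc(-n2ncc3c(N)ncnc32)cc1`, differs from compound 1 in one place: ((methoxycarbonyl)methyl)carbamoyl in place of cyano on an aromatic carbon. Among the measured compounds shown here, no step between two measured compounds is known here, so neither the size nor the direction of this change can be read from the data; a shift either way, or none beyond the usual scatter, remains open. On the showing of the set, compound 4 is expected to inhibit growth only weakly, at about 60000 nM, in an estimated range from 5000 nM to 300000 nM, with a real chance that the assay again reports only a limit.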

Compound 4, concentration for 50% growth inhibition: > 150000 nM
Compound 4 gave a limit, no number (the forecaster's own chance of this, stated with the estimate: 50%); at least 2.5-fold (0.39 log units) between middle value and limit.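

In this assay compound 4 gives > 150000 nM, which is a limit of the assay and not a number. Among these compounds, compound 1 has no number of its own, and no step from it to compound 4 can be read. As far as these compounds go, whether placing ((methoxycarbonyl)methyl)carbamoyl where cyano stood changes growth inhibition at all, and in which direction, stays open.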